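This account rests on a few compounds, and the source may have more. Where it says the series, first, only, none or still open, it means among the compounds named here.

Within the data shown here, in an ADME assay on BJ cells (Homo sapiens) for cytotoxicity, read by MTT assay, with a stated time of 72 h (a higher number here means that more compound is tolerated, a lower number that less compound is tolerated), compound 2 `OC[C@H]1O[C@@H](n2cc(F)c3c(-c4cc[nH]c4)ncnc32)[C@H](O)[C@@H]1O` stands higher of the two measured so far, at 2020 nM against compound 1 `OC[C@H]1O[C@@H](n2cc(F)c3c(-c4ccco4)ncnc32)[C@H](O)[C@@H]1O` at 310 nM in the same test. Compound 3 `OC[C@H]1O[C@@H](n2cc(F)c3c(-c4nccs4)ncnc32)[C@H](O)[C@@H]1O` differs from compound 2 in one group on an aromatic carbon (1,3-thiazol-2-yl in place of 1H-pyrrol-3-yl on an aromatic carbon). Among the measured compounds shown here, one measured step bears on this, also an exchange of one five-membered aromatic ring for another (a 6.5-fold higher number from compound 1 to compound 2 (0.81 log units; beyond the scatter)), and it is modest in size. A single step cannot fix a direction, but with compound 2 at the upper end, a modest drop is expected (a 2.2-fold lower number from compound 2 to compound 3 (0.35 log units; beyond the scatter)). Compound 3 is estimated at 900 nM within an expected range from 200 nM to 5000 nM for now.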

Compound 3, half-maximal cytotoxic concentration: 630 nM
Compound 3: the middle estimate sits 1.4-fold (0.15 log units) above what was measured, and the stated range covers the measured number.
By their numbers in this assay, from the lowest: compound 1; then compound 3; then compound 2.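

Placing 1,3-thiazol-2-yl on this carbon gives a 3.2-fold lower number from compound 2 to compound 3 (0.51 log units; beyond the scatter) and a 2.0-fold higher number from compound 1 to compound 3 (0.31 log units; beyond the scatter), so in this assay this ring falls between the other two. Three five-membered aromatic rings now give three separate numbers, and the number shifts even between 1H-pyrrol-3-yl and 1,3-thiazol-2-yl, which have the same heavy-atom count. Nothing available explains these differences. Going by these compounds, how a phenyl ring or an amine on this same carbon would compare remains open.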